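The source may report more compounds than this note shows. Statements on the series, on what has been measured and on what is new or still open speak of the compounds shown alone.

Compound 1 `COc1ncnc2c1c(-c1ccsc1)cn2[C@@H]1O[C@H](CO)[C@@H](O)[C@H]1O` gives 120 nM in a functional assay on HCT-116 cells (Homo sapiens), read by MTT assay, with a stated time of 72 h; on this read-out lower numbers stand for stronger inhibition and higher numbers for weaker inhibition.
Compound 2 `COc1ncnc2c1c(-c1cccs1)cn2[C@@H]1O[C@H](CO)[C@@H](O)[C@H]1O` gives 80 nM in this assay.
Compound 3 `COc1ncnc2c1c(I)cn2[C@@H]1O[C@H](CO)[C@@H](O)[C@H]1O` gives only a limit, > 20000 nM, in this assay.

Compound 3 therefore stands apart from the other two: its result is a limit and not a number, namely (the limit of > 20000 nM in this assay, at which 1 of the 3 values shown sits), so its potency is only bounded from one side. Compound 4 `COc1ncnc2c1c(-c1ccco1)cn2[C@@H]1O[C@H](CO)[C@@H](O)[C@H]1O` differs from compound 3 in one place: furan-2-yl in place of iodo on an aromatic carbon. Within the data shown here, two measured steps bear on this change, both running the opposite way, from thiophen-3-yl or thiophen-2-yl to iodo: an at least 160-fold higher number from compound 1 to compound 3 (2.22 log units; beyond the scatter) and an at least 250-fold higher number from compound 2 to compound 3 (2.39 log units; beyond the scatter). Putting a five-membered aromatic ring back in place of iodo is therefore expected to give a large step toward lower numbers in this assay, an at least 130-fold lower number from compound 3 to compound 4 (2.12 log units; beyond the scatter). Compound 4 is expected at about 150 nM, within a range from 40 nM to 800 nM.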

Compound 4, half-maximal inhibitory concentration: 40 nM
Beside the measured number, compound 4's estimate is 3.8-fold (0.57 log units) above it; the range from low to high includes it.
By their numbers in this assay, from the lowest: compounds 4, 2 and 1 (each within the scatter of the next, the first and the last beyond it). At a limit, above all of these: compound 3.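

The earlier compounds shown here carried only thiophene rings at this aromatic carbon, and compound 4 shows that a furan-2-yl ring can also take the place of iodo in this assay, with an at least 500-fold lower number from compound 3 to compound 4 (2.69 log units; beyond the scatter). The choice of ring changes the result little, with a 2.0-fold lower number from compound 2 to compound 4 (0.30 log units; within the scatter) and a 3.0-fold lower number from compound 1 to compound 4 (0.48 log units; beyond the scatter). The first of these steps is only bounded, since compound 3 gives a limit: the limit of > 20000 nM in this assay, at which 1 of the 4 values shown sits.

Still open, going by these compounds, is whether a five-membered aromatic ring is needed here, or whether a phenyl ring, a methyl group or an amine at this carbon would give similar numbers.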